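A few compounds are considered here, and "the series" means these few. Any claim that something is new, unique, unknown or untested is made for them only; others in the source may bear on it.

Of the compounds shown here, three that share one core have been measured in a physicochemical assay for solubility, read by HPLC, in phosphate buffer, measured as kinetic solubility, at pH 7.4; a higher number here means a more soluble compound, a lower number a less soluble compound. Compound 1 `CCC(=O)c1ccn(-c2ccc(S(N)(=O)=O)cc2)c1C` gives 100000 nM. Compound 2 `CCC(=O)c1cc(-c2ccc(OC)cc2)n(-c2ccc(S(N)(=O)=O)cc2)c1C` has a 4-methoxyphenyl in place of hydrogen on an aromatic carbon and gives 12800 nM. Compound 3 `CCC(=O)c1cc(-c2ccc(Cl)cc2Cl)n(-c2ccc(S(N)(=O)=O)cc2)c1C` has a 2,4-dichlorophenyl in place of that hydrogen and gives 7700 nM. Compound 2 therefore stands well under compound 1 and level with compound 3 once the usual scatter is allowed for.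

Compound 4 `CCOC(=O)c1cc(-c2ccc(OC)cc2)n(-c2ccc(S(N)(=O)=O)cc2)c1C` differs from compound 2 in one group: ethoxy in place of ethyl on a carbonyl carbon. This is ethoxy in place of ethyl on a carbonyl carbon, so propanoyl becomes ethoxycarbonyl.

Going by the values given here, no measured step involves this carbonyl, so the evidence is indirect. The two big moves, a 7.8-fold lower number from compound 1 to compound 2 (0.89 log units; beyond the scatter) and a 13-fold lower number from compound 1 to compound 3 (1.11 log units; beyond the scatter), came from adding a whole aromatic group where there had been only hydrogen, which is a different kind of change. The closer guide is a swap of one group for another, a 1.7-fold lower number from compound 2 to compound 3 (0.22 log units; within the scatter), though it happened at a different place.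

A step beyond the scatter in this assay is therefore not expected, and the estimated step is a 1.3-fold lower number from compound 2 to compound 4 (0.11 log units; within the scatter). The estimate for compound 4 is 10000 nM, with an expected range from 4000 nM to 25000 nM.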

Compound 4, solubility: 16100 nM
For compound 4 the middle estimate is 1.6-fold (0.21 log units) below the measured one; the range from low to high includes it.
By their numbers in this assay, from the lowest: compounds 3, 2 and 4 (each within the scatter of the next, the first and the last beyond it); then compound 1.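

Going by these compounds alone, this is the first measured change on the carbonyl carbon, and in this assay the swap of ethyl for ethoxy gives a 1.3-fold higher number from compound 2 to compound 4 (0.10 log units; within the scatter), a step too small to separate the two groups. Propanoyl and ethoxycarbonyl therefore cannot be told apart in this assay when the rest of the molecule is that of compound 2, even though ethoxy carries an oxygen and a hydrogen-bond acceptor that ethyl does not. No measurement shown here explains why the added atom leaves the number within the usual scatter.

As far as these compounds go, this single pair speaks for one setting only, so it remains open whether the same swap would stay as small alongside a 2,4-dichlorophenyl group, or with only hydrogen at that aromatic carbon, as in compound 1. It also leaves open how the read-out would respond to a group that differs more from ethyl or ethoxy on the carbonyl carbon, such as an amine, a hydroxyl group that would make a carboxylic acid, or a longer chain.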